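Aryl Swap on a Cyclopropane-Fused Hydroxamate Core

The compounds below may be only part of what the source reports. "The series", "measured", "known", "first", "only" and "open" are said of these compounds alone.

This account concerns a small set of hydroxamic acids assayed in an assay on isolated protein for binding affinity to disintegrin and metalloproteinase domain-containing protein 10 (Homo sapiens); on this read-out higher numbers stand for weaker inhibition and lower numbers for stronger inhibition. Compound 1 `COC(=O)N1CC2(CC2)C[C@H](C(=O)NO)[C@H]1C(=O)N1CC=C(c2ccccc2)C1` gives 26 nM in this assay. Compound 2 `CC(C)c1cccc(N2CCN(C(=O)[C@H]3NCC4(CC4)C[C@@H]3C(=O)NO)CC2)c1` gives 1100 nM in this assay. Compound 3 `O=C(NO)[C@H]1CC2(CC2)CN[C@@H]1C(=O)N1CC=C(c2cc(Cl)cc(Cl)c2)CC1` gives 99 nM in this assay. Among the three numbers, compound 3 stands second highest: its nearest neighbour is compound 1, whose number is lower by a margin beyond the scatter, while compound 2 lies furthest away with a number higher by a margin also beyond the scatter.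

The step under consideration leads from compound 3 to compound 4 `COc1cccc(C2=CCN(C(=O)[C@H]3NCC4(CC4)C[C@@H]3C(=O)NO)CC2)c1`, which has not yet been measured in this assay. The two structures differ in one place: 3-methoxyphenyl in place of 3,5-dichlorophenyl on a double-bonded ring carbon. Going by the values given here, no pair of measured compounds in this set differs by only this change, so the effect of the swap has no direct precedent here. The three measured compounds carry three different aryl groups on three different amide-bearing rings, and their numbers spread across a wide range without isolating the aryl contribution.

The author therefore expects a modest step from compound 3 to compound 4 of a 1.5-fold higher number from compound 3 to compound 4 (0.18 log units; within the scatter), most likely toward a weaker number, but of a size that may not exceed the scatter. For compound 4 the estimate in this assay is 150 nM, with a range from 50 nM to 500 nM.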

Compound 4, half-maximal inhibitory concentration: 40 nM
Compound 4: the middle estimate sits 3.8-fold (0.57 log units) above what was measured; measured number below the stated range.
By their numbers in this assay, from the lowest: compounds 1 and 4 (each within the scatter of the next); then compound 3; then compound 2.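

In this assay, going by these compounds alone, the exchange of 3,5-dichlorophenyl for 3-methoxyphenyl on a double-bonded ring carbon gives a 2.5-fold lower number from compound 3 to compound 4 (0.39 log units; beyond the scatter) and is the first step in this set in which only the aryl group changes. It shows that the number responds to the aryl group at this position, and that the two chlorine atoms are not required for inhibition of this order: the entering group, with the same count of heavy atoms and one hydrogen-bond acceptor where the leaving group has none, gives the stronger inhibition of the pair. No measurement available here accounts for the direction of this step.

The compounds shown leave open whether the step comes from the methoxy group entering or from the chlorine atoms leaving, a question that a single 3-chlorophenyl group or a bare phenyl group on the same six-membered ring would separate. They also leave open how far this position tolerates other groups in the same place, such as a hydroxyl, an ethoxy group or a dimethylamino group.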